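The compounds below may be only part of what the source reports. "The series", "measured", "known", "first", "only" and "open" are said of these compounds alone.

Within the data shown here, compound 1 `COc1cc(-c2cc(/C=C/C(=O)c3ccc(N)cc3)[nH]n2)cc(OC)c1OC` is one of three compounds measured in a functional assay on SF-539 cells (Homo sapiens) for cytotoxicity, read by sulforhodamine B assay, with a stated time of 48 h, tested at 10 uM (a lower number here means a stronger effect, a higher number a weaker effect of the compound at the concentration tested), where compound 1 gives -93%. Compound 2 `COc1ccc(-c2cc(/C=C/C(=O)c3ccc(OC)c(OC)c3)[nH]n2)cc1` gives -93%, the same figure at the digits shown, so the two stand together at the lowest end of the set. Among the measured compounds shown here, compound 3 `COc1cc(-c2cc(/C=C/C(=O)c3ccc(Cl)c(Cl)c3)[nH]n2)cc(OC)c1OC` gives 28%, which is far weaker; the only single-site step measured, a number 121 percentage points higher from compound 1 to compound 3 (beyond the scatter), shows how strongly the group on the carbonyl carbon can matter.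

Compound 4 `COc1ccc(-c2cc(/C=C/C(=O)c3ccc(N)cc3)[nH]n2)cc1OC` differs from compound 1 at a different place: hydrogen in place of methoxy on an aromatic carbon, on an aromatic carbon of the six-membered ring of carbon only, ortho to one methoxy group and meta to another. For the measured compounds named here, no measured step covers this particular change, since the only step measured concerns the group on the carbonyl carbon. Compound 2, which carries fewer methoxy groups on its ring but a different ketone partner, still gives a number level with compound 1, which hints that trimming a methoxy group need not cost much. The expectation is therefore a step of about a number 8 percentage points higher from compound 1 to compound 4 (within the scatter) in this assay, within the usual scatter. Compound 4 is estimated at -85%, with a likely range from -100% to -40%.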

Compound 4, a percentage reported as activity, at one concentration (the size of the read-out at that concentration, not a potency): -73%
Estimate against measurement, compound 4: 12 percentage points below, within the range that was stated.
By their numbers in this assay, from the lowest: compounds 1 and 2 (each within the scatter of the next); then compound 4; then compound 3.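

In this assay, among these compounds, hydrogen in place of methoxy on this aromatic carbon, ortho to a methoxy group, gives a number 20 percentage points higher from compound 1 to compound 4 (beyond the scatter), so this one methoxy group of compound 1 makes a measurable difference to the read-out, a point the earlier compounds could not settle. The change is modest, and compound 4 stays on the negative side at -73%, whereas the large step at the carbonyl carbon, a number 121 percentage points higher from compound 1 to compound 3 (beyond the scatter), carries the number to a positive value, so within this small set the methoxy position tunes the result less sharply than the group on the carbonyl carbon does. Nothing measured here explains why removing this methoxy group has this effect.

The compounds shown leave open how a hydroxyl group, a fluorine atom or an ethoxy group on this same carbon would compare with methoxy and hydrogen. They also leave open whether removing this methoxy group would have a step of similar size when the carbonyl carbon carries the 3,4-dichlorophenyl group of compound 3 rather than the 4-aminophenyl group of compound 1.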